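The source may report more compounds than this note shows. Statements on the series, on what has been measured and on what is new or still open speak of the compounds shown alone.

Within the data shown here, in a functional assay on CHO.K1 cells for antagonist activity at prostaglandin D2 receptor 2 (Homo sapiens), read by GTPgammaS binding, with a stated time of 1 h (a lower number here means a stronger inhibitor, a higher number a weaker inhibitor), compound 3 `CCS(=O)(=O)c1ccccc1Cc1c2c(n(CC(=O)O)c1C)CCNC2=O` gives 550 nM, the highest of the three numbers measured so far. Compound 1 `CNC(=O)c1cccc(S(=O)(=O)c2ccccc2Cc2c3c(n(CC(=O)O)c2C)CCNC3=O)c1` gives 240 nM in this assay, and compound 2 `Cc1c(Cc2ccccc2S(=O)(=O)c2ccc(OC(F)(F)F)cc2)c2c(n1CC(=O)O)CCNC2=O` gives 6.6 nM; the two aryl sulfones are separated by the step of a 36-fold lower number from compound 1 to compound 2 (1.56 log units; beyond the scatter). The change now in question is benzyl(methyl)amino in place of ethyl on a sulfonyl sulfur, which leads to compound 4 `Cc1c(Cc2ccccc2S(=O)(=O)N(C)Cc2ccccc2)c2c(n1CC(=O)O)CCNC2=O`. Two of the measured steps concern the same ethyl group on the sulfonyl sulfur: a 2.3-fold higher number from compound 1 to compound 3 (0.36 log units; beyond the scatter) and an 83-fold higher number from compound 2 to compound 3 (1.92 log units; beyond the scatter). Read in the opposite direction, both replacements of ethyl by a group carrying a six-membered aromatic ring gave a lower number, one modestly and one by a large margin. Among the measured compounds shown here, the entering benzyl(methyl)amino group likewise carries one six-membered aromatic ring of carbon only, but it is an amino group on the sulfonyl sulfur, a feature none of the measured compounds shares, so the precedent is only partial. A lower number than that of compound 3 is therefore expected, of a size between the two measured steps, and the estimated step is a 5.5-fold lower number from compound 3 to compound 4 (0.74 log units; beyond the scatter). Compound 4 is estimated at 100 nM, within a range from 20 nM to 600 nM.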

Compound 4, half-maximal inhibitory concentration: 26 nM
Estimate against measurement, compound 4: 3.8-fold (0.59 log units) above; low and high end bracket the measured number.
By their numbers in this assay, from the lowest: compound 2; then compound 4; then compound 1; then compound 3.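

In this assay the sulfonyl sulfur, seen so far only with carbon groups, also accepts an amino group: a 21-fold lower number from compound 3 to compound 4 (1.33 log units; beyond the scatter) shows that a six-membered aromatic ring of carbon only can lower the number when it enters as part of benzyl(methyl)amino rather than as an aryl group on the sulfur. Set against the two aryl sulfones, the new group falls on both sides, with a 9.2-fold lower number from compound 1 to compound 4 (0.97 log units; beyond the scatter) in one direction and a 3.9-fold higher number from compound 2 to compound 4 (0.60 log units; beyond the scatter) in the other, so the amino group does not stand above or below aryl groups as a class, and the choice of aryl group decides the order. Nothing available explains any of these steps.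

The compounds shown leave open which part of benzyl(methyl)amino accounts for the drop from ethyl: dimethylamino would test the amino group without the ring, and benzylamino would test the ring without the methyl on nitrogen. As far as these compounds go, it is also open whether the trifluoromethoxy group that accompanies the lowest number here would lower the number further on the benzyl ring.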